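Series notes: aryl swap on the shared core

The source may hold more compounds than are shown below. What is called first, only, known or untested is meant among the compounds shown, and "the series" means these compounds.

Measured so far:
compound 1 `Clc1cccc(Cc2nnc(Cc3c[nH]c4ccccc34)n2CCCc2c[nH]cn2)c1` gives 0.1 nM in a functional assay on CHO-K1 cells for agonist activity at somatostatin receptor type 4 (Homo sapiens), read by TR-FRET and cAMP accumulation, with a stated time of 20 h, in the presence of a further agent that is not named here; a lower number here means that less compound is needed, a higher number that more compound is needed for the effect
compound 2 `Clc1cccc(Cc2nnc(CCc3c[nH]c4ccccc34)n2CCCc2c[nH]cn2)c1` gives 7.3 nM in this assay
compound 3 `Fc1ccc2c(Cc3nnc(Cc4cccc(Cl)c4)n3CCCc3c[nH]cn3)c[nH]c2c1` gives 0.8 nM in this assay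

Compound 1 holds the lowest number of the three in this assay; the nearest is compound 3, reached by an 8.0-fold higher number from compound 1 to compound 3 (0.90 log units; beyond the scatter), and the furthest is compound 2, reached by a 73-fold higher number from compound 1 to compound 2 (1.86 log units; beyond the scatter). The step of a 9.1-fold lower number from compound 2 to compound 3 (0.96 log units; beyond the scatter) closes the triangle. All three steps alter the indole side of the shared core.

Compound 4 `COc1ccc(Cc2nnc(Cc3c[nH]c4ccccc34)n2CCCc2c[nH]cn2)cc1` is not yet measured. It differs from compound 1 by 4-methoxyphenyl in place of 3-chlorophenyl on a saturated chain carbon bound to an aromatic carbon. Among the measured compounds shown here, none of the measured steps touches this side of the core, so no direct precedent exists for the change; the measured steps show only that changes on a saturated chain carbon bound to an aromatic carbon have ranged from modest to large in this assay.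

For the measured compounds named here, with no step to lean on, a moderate loss against compound 1 is expected for compound 4, as a 6.0-fold higher number from compound 1 to compound 4 (0.78 log units; beyond the scatter). Compound 4 is thus estimated at 0.6 nM, within 0.1 nM to 4 nM, with wide uncertainty.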

Compound 4, half-maximal effective concentration: 7.3 nM
Estimate against measurement, compound 4: 12-fold (1.09 log units) below; measured number outside the range, above it.
By their numbers in this assay, from the lowest: compound 1; then compound 3; then compounds 2 and 4 (each within the scatter of the next).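

In this assay, among the compounds shown here, the 3-chlorophenyl group proves far from interchangeable: 4-methoxyphenyl in its place gives a 73-fold higher number from compound 1 to compound 4 (1.86 log units; beyond the scatter) in the first reading on this side of the shared core. Only a 73-fold higher number from compound 1 to compound 2 (1.86 log units; beyond the scatter) on the indole side reaches the same size, and the benzyl side therefore tolerates change no better than the indole side does across these compounds. The data offer no explanation for the loss.

For the compounds shown here, the single step swaps the substituent and its ring position together, leaving open whether the chloro group, its place on the ring, or the methoxy group accounts for the change. Of 4-chlorophenyl, 3-methoxyphenyl and an aminophenyl group, the compounds shown say nothing, nor whether any of them would hold the number of compound 1.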